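Swapping the aryl group on the hydrazone carbon of compound 2

A few compounds are considered here, and "the series" means these few. Any claim that something is new, unique, unknown or untested is made for them only; others in the source may bear on it.

Of the compounds shown here, two sharing one core have been measured. Compound 1 `NS(=O)(=O)c1ccc(Nc2nc(N/N=C/c3ccc(C(F)(F)F)cc3)nc(Nc3ccccc3)n2)cc1` gives 2960 nM in a functional assay on OVCAR-5 cells (Homo sapiens) for inhibition, read by sulforhodamine B assay, with a stated time of 48 h; on this read-out higher numbers stand for weaker inhibition of growth and lower numbers for stronger inhibition of growth. Compound 2 `Cc1nn(-c2ccccc2)cc1/C=N/Nc1nc(Nc2ccccc2)nc(Nc2ccc(S(N)(=O)=O)cc2)n1` gives 2060 nM in this assay. The step of a 1.4-fold lower number from compound 1 to compound 2 (0.16 log units; within the scatter) comes from exchanging one aryl group on the carbon with a double bond to nitrogen. Among the compounds with values here, compound 2 therefore stands on one of only two numbers, and its distance to compound 1 is within the scatter, so the two cannot be told apart.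

Compound 3 `NS(=O)(=O)c1ccc(Nc2nc(N/N=C/c3ccccn3)nc(Nc3ccccc3)n2)cc1` repeats this kind of exchange at the same place: pyridin-2-yl in place of 3-methyl-1-phenyl-1H-pyrazol-4-yl on a carbon with a double bond to nitrogen. Within the data shown here, only one measured step bears on it, the step from compound 1 to compound 2, which changed the same position and stayed within the scatter. With no sign that this position moves the numbers, compound 3 is expected to land close to compound 2, with an expected step of a 1.2-fold higher number from compound 2 to compound 3 (0.08 log units; within the scatter) that stays within the scatter. Compound 3 is thus estimated at 2500 nM in this assay, with a range from 800 nM to 8000 nM.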

Compound 3, concentration for 50% growth inhibition: 1600 nM
Compound 3: middle estimate off by 1.6-fold (0.19 log units), on the high side, and the stated range covers the measured number.
By their numbers in this assay, from the lowest: compounds 3, 2 and 1 (each within the scatter of the next).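

Exchanging 3-methyl-1-phenyl-1H-pyrazol-4-yl for pyridin-2-yl on the carbon with a double bond to nitrogen gives a small step (a 1.3-fold lower number from compound 2 to compound 3 (0.11 log units; within the scatter)), and exchanging 4-(trifluoromethyl)phenyl for pyridin-2-yl gives a similar result (a 1.9-fold lower number from compound 1 to compound 3 (0.27 log units; within the scatter)). In this assay, this position now tolerates a two-ring group, a substituted carbon-only ring and a single ring containing nitrogen, yet all three compounds remain within the scatter of one another, even though pyridin-2-yl has one aromatic ring where 3-methyl-1-phenyl-1H-pyrazol-4-yl has two. The comparison therefore extends the earlier finding from one exchange to three aryl groups, while no measurement shown offers an explanation for the lack of separation.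

As far as these compounds go, all three groups at this position are aromatic rings, so it remains open whether a carboxylic acid, an amine or a longer alkyl chain there would move the number beyond the scatter. From the compounds shown here alone, only this one position varies on the shared core, so the response to changes elsewhere on the core also remains open.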